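From compound 3 to compound 4: an aryl exchange

The compounds below may be only part of what the source reports. "The series", "measured", "known", "first", "only" and "open" are said of these compounds alone.

In a physicochemical assay for solubility, in phosphate buffer, measured as kinetic solubility, at pH 7.4 (on this read-out lower numbers stand for lower solubility and higher numbers for higher solubility), compound 3 `Cc1oc(-c2c(Cl)cccc2C(F)(F)F)nc1CN1CCC(C(=O)NCCCN2C[C@H](C)C[C@H](C)C2)CC1` gives 65.1 ug/mL and lies within the scatter of its nearest neighbour. That neighbour is compound 2 `Cc1oc(-c2c(Br)cccc2Br)nc1CN1CCC(C(=O)NCCCN2C[C@H](C)C[C@H](C)C2)CC1` with 62.4 ug/mL as its reading, so the two cannot be ranked. Compound 1 `Cc1ccccc1-c1nc(CN2CCC(C(=O)NCCCN3[C@H](C)CCC[C@@H]3C)CC2)c(C)o1` is reported as > 69 ug/mL and that is a limit, not a number.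

Compound 4 `Cc1cccc(C)c1-c1nc(CN2CCC(C(=O)NCCCN3C[C@H](C)C[C@H](C)C3)CC2)c(C)o1` has not yet been measured. It differs from compound 3 by a single exchange: 2,6-dimethylphenyl in place of 2-chloro-6-(trifluoromethyl)phenyl on an aromatic carbon that is, 2,6-dimethylphenyl in place of 2-chloro-6-(trifluoromethyl)phenyl, on an aromatic carbon of a five-membered aromatic ring with 1 nitrogen and 1 oxygen.

Within the data shown here, only one measured step bears on this place: a 1.0-fold higher number from compound 2 to compound 3 (0.02 log units; within the scatter) and it stays within the scatter although 2,6-dibromophenyl gave way to 2-chloro-6-(trifluoromethyl)phenyl. The estimate must also reckon with the limit of > 69 ug/mL in this assay, at which 1 of the 3 values shown sits, since compound 4 could be reported as a limit too. Resting on that single step, no shift beyond the scatter is expected in this assay in either direction. The estimated change is a 1.1-fold lower number from compound 3 to compound 4 (0.02 log units; within the scatter) and no more than that is expected. For compound 4 the estimated solubility is 62 ug/mL with an expected range from 40 ug/mL to 75 ug/mL as its bounds.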

Compound 4, solubility: 55.9 ug/mL
For compound 4 the middle estimate is 1.1-fold (0.04 log units) above the measured one, and the stated range covers the measured number.
By their numbers in this assay, from the lowest: compounds 4, 2 and 3 (each within the scatter of the next). At a limit, above all of these: compound 1.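

In this assay, the exchange of 2-chloro-6-(trifluoromethyl)phenyl, with 11 heavy atoms including fluorine and chlorine, for 2,6-dimethylphenyl, with 8 heavy atoms that are all carbon, stays within the scatter: a 1.2-fold lower number from compound 3 to compound 4 (0.07 log units; within the scatter). The direct comparison with 2,6-dibromophenyl gives the same outcome: a 1.1-fold lower number from compound 2 to compound 4 (0.05 log units; within the scatter). Among these compounds, the earlier step compared only two groups that both carried halogen atoms, whereas these steps show that an aryl group with carbon alone also gives a reading that cannot be ranked against compound 2 or compound 3, so the three groups cannot be told apart at this position on the shared core.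

On these data alone, compound 1 differs from these compounds in more than one place and is reported as a limit, not a number: the limit of > 69 ug/mL in this assay, at which 1 of the 4 values shown sits. It remains open whether an aryl group carrying an amine or a carboxylic acid at this position, on the same core, would move the reading in this assay beyond the scatter.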